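The compounds below may be only part of what the source reports. "The series", "measured", "known", "first", "only" and "open" are said of these compounds alone.

Working notes on the amide series in a functional assay on the whole organism (strain Wistar) for inhibition, with Rattus norvegicus as the target, read by paw edema, with stated times of 60 min and 1 h, at a dose of 100 mg/kg by the oral route; on this read-out lower numbers stand for less inhibition and higher numbers for more inhibition at the one dose given (going by the name of the read-out). The shared core carries a two-carbon chain ending in an amide; the amide nitrogen varies. Compound 1 `CCNC(=O)CC1CCc2cc(OC)c(OC)cc21` gives 15.6%. Compound 2 `COc1cc2c(cc1OC)C(CC(=O)NC(C)C)CC2` gives 31.3%, and compound 3 `COc1cc2c(cc1OC)C(CC(=O)NC(C)(C)C)CC2` gives 31.3%. Two steps rise: a number 15.7 percentage points higher from compound 1 to compound 2 (beyond the scatter) and a number 15.7 percentage points higher from compound 1 to compound 3 (beyond the scatter), both modest. Between the two branched amides there is no change at the digits printed from compound 2 to compound 3 (within the scatter). Compound 3 therefore stands level with compound 2, the two together at the top of the three numbers, and clear of compound 1.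

Next is compound 4 `COc1cc2c(cc1OC)C(CC(=O)N1CCNCC1)CC2`, with piperazin-1-yl in place of (tert-butyl)amino on a carbonyl carbon. For the measured compounds named here, no measured step replaces the amino group with a ring amine; the three measured steps only change the alkyl group on the nitrogen, and the two that moved were modest while the one between branched groups was flat. The change is expected to leave this assay about where compound 3 stands, with a number 3.3 percentage points lower from compound 3 to compound 4 (within the scatter) as the expected step. Compound 4 is estimated at 28%, in the range 10% to 46%.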

Compound 4, a percentage reported as inhibition, in the whole organism at one dose (the size of the read-out at that dose, not a potency): 62.5%
Beside the measured number, compound 4's estimate is 34.5 percentage points below it; measured number above the stated range.
By their numbers in this assay, from the lowest: compound 1; then compounds 2 and 3 (each within the scatter of the next); then compound 4.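

In this assay, the substituent on the carbonyl carbon can move the number much further than the earlier alkyl changes did: piperazin-1-yl gives a number 31.2 percentage points higher from compound 3 to compound 4 (beyond the scatter) and a number 31.2 percentage points higher from compound 2 to compound 4 (beyond the scatter) and also a number 46.9 percentage points higher from compound 1 to compound 4 (beyond the scatter) in the three steps measured. For the compounds shown here, each of these steps is large, whereas the earlier steps among ethylamino, isopropylamino and (tert-butyl)amino were modest or flat, so compound 4 stands clear of all three open-chain amides. No measurement here accounts for this rise.

The compounds shown leave open whether the rise belongs to the six-membered ring itself or to its second nitrogen, a question that piperidin-1-yl or morpholin-4-yl on the same carbonyl carbon would address. Also open, on these data alone, is how far the number holds with 4-methylpiperazin-1-yl in place of piperazin-1-yl.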